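This account rests on a few compounds, and the source may have more. Where it says the series, first, only, none or still open, it means among the compounds named here.

Going by the values given here, in an ADME assay on MT4 cells (Homo sapiens) for cytotoxicity, with a stated time of 5 days (a lower number here means that less compound is tolerated, a higher number that more compound is tolerated), compound 1 `CC(C)(C)C#Cc1cc(N(C(=O)[C@H]2CC[C@H](C)CC2)[C@H]2CC[C@H](Oc3ccc4nccn4n3)CC2)c(C(=O)O)s1` gives 133 nM and holds the lower of the two numbers so far. Compound 2 `CC(C)(C)C#Cc1cc(N(C(=O)[C@H]2CC[C@H](C)CC2)[C@H]2CC[C@](O)(CO[C@H]3CCOC3)CC2)c(C(=O)O)s1` gives 8980 nM and stands beyond the scatter from it, but differs from it in more than one place. Compound 3 `CC(C)(C)C#Cc1cc(N(C(=O)[C@H]2CC[C@H](C)CC2)[C@H]2CC[C@H](OC3CCOCC3)CC2)c(C(=O)O)s1` departs from compound 1 by a single change (a group of 6 heavy atoms (5 carbon, 1 oxygen; one six-membered non-aromatic ring with 1 hetero atom) in place of a group of 9 heavy atoms (6 carbon, 3 nitrogen; one five-membered aromatic ring with 2 hetero atoms, one six-membered aromatic ring with 2 hetero atoms), on an oxygen on a saturated carbon). Among the compounds with values here, no measured single-place step is available as a guide. A large rise beyond the scatter is expected, resting on compound 2 at 8980 nM with its saturated oxygen-bearing ring. The expected size is a 45-fold higher number from compound 1 to compound 3 (1.65 log units; beyond the scatter) on this estimate. For compound 3 the estimated value is 6000 nM with 1000 nM to 30000 nM as its range.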

Compound 3, half-maximal cytotoxic concentration: 1990 nM
Compound 3: the middle estimate sits 3.0-fold (0.48 log units) above what was measured; low and high end bracket the measured number.
By their numbers in this assay, from the lowest: compound 1; then compound 3; then compound 2.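

Going by these compounds alone, at the oxygen on a saturated carbon, oxan-4-yl in place of the group with a five-membered and a six-membered aromatic ring gives the first single-place step in this assay: a 15-fold higher number from compound 1 to compound 3 (1.18 log units; beyond the scatter). This one position alone therefore moves the read-out well beyond the scatter, with the rest of the core of compound 1 unchanged. No measured finding on hand accounts for this step.

From the compounds shown here alone, whether the rise follows the loss of the aromatic rings or the exchange of nitrogen for oxygen stays open. A phenyl group or a plain butyl chain on this oxygen would help separate the two.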